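The compounds below may be only part of what the source reports. "The series", "measured", "known", "first", "only" and "open" are said of these compounds alone.

Within the data shown here, in a functional assay on HepG2 cells (Homo sapiens) for cytotoxicity, read by MTT assay, with a stated time of 72 h (on this read-out higher numbers stand for weaker inhibition and lower numbers for stronger inhibition), compound 1 `Nc1ccccc1NC(=O)c1ccc(NC(=O)NCc2ccc(Cl)nc2)cc1` gives 2400 nM, the lower of the two numbers so far. Compound 2 `Cc1ccc(CNC(=S)Nc2ccc(C(=O)Nc3ccccc3N)cc2)cn1` gives 11000 nM, a difference beyond the scatter. Compound 3 `Nc1ccc(CNC(=O)Nc2ccc(C(=O)Nc3ccccc3N)cc2)cn1` keeps the core of compound 1 but carries amino in place of chloro on an aromatic carbon. Among the measured compounds shown here, no measured pair shows this change, so the expectation is loose. A modest rise to a weaker number, near the edge of the scatter, is expected, an estimated step of a 2.1-fold higher number from compound 1 to compound 3 (0.32 log units; beyond the scatter). The estimate for compound 3 is 5000 nM, with an expected range of 1500 nM to 15000 nM.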

Compound 3, half-maximal inhibitory concentration: 3100 nM
Beside the measured number, compound 3's estimate is 1.6-fold (0.21 log units) above it; low and high end bracket the measured number.
By their numbers in this assay, from the lowest: compounds 1 and 3 (each within the scatter of the next); then compound 2.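

Among these compounds, this is the first pair to isolate this position. In this assay, the step from 6-chloropyridin-3-yl to 6-aminopyridin-3-yl is a 1.3-fold higher number from compound 1 to compound 3 (0.11 log units; within the scatter), so the two groups cannot be told apart here. On this carbon next to the ring nitrogen, then, amino, with its hydrogen-bond donor and acceptor, serves as well as chloro in this assay, and no measurement available here accounts for that.

As far as these compounds go, what a methoxy group or a carboxylic acid on the same carbon would give remains open. So does whether amino and chloro also match on a different core.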